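Cytotoxicity notes on a chain-extended amide series

The source may hold more compounds than are shown below. What is called first, only, known or untested is meant among the compounds shown, and "the series" means these compounds.

Compound 1 `CCCCNc1nccnc1C(=O)NCc1ccccc1`: in an ADME assay on HeLa cells (Homo sapiens) for cytotoxicity, read by microscopy, with a stated time of 6 days (on this read-out higher numbers stand for lower toxicity in this test and lower numbers for higher toxicity in this test), compound 1 gives > 100000 nM, a limit of the assay rather than a number.
Compound 2 `CCCCCNc1nccnc1C(=O)NCc1ccccc1`: in this assay compound 2 gives > 100000 nM, again a limit.
Compound 3 `CCCCNc1cncc(C(=O)NCc2ccccc2)n1`: in this assay compound 3 gives > 100000 nM, again a limit.

Compound 3 therefore stands only at a limit, and the whole series does the same: the limit of > 100000 nM in this assay, at which 3 of the 3 values shown sit. Within the data shown here, the one measured step, a step that the two limits leave unreadable from compound 1 to compound 2, is of a related kind, but the two limits leave its size unreadable, so no measured step gives a size that bears on the change at hand.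

Compound 4 `CCCCCCCNc1cncc(C(=O)NCc2ccccc2)n1` differs from compound 3 by propyl in place of hydrogen on a saturated chain carbon, four bonds along the chain from a nitrogen on an aromatic ring.

With nothing readable to go on, no step beyond the scatter is expected. Compound 4 is expected to give 100000 nM in this assay, with a range from 40000 nM to 300000 nM. The expected step of a number no higher from compound 3 to compound 4 (the limit leaves the size open) is thus none beyond the scatter, most likely another limit.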

Compound 4, minimum cytotoxic concentration: > 100000 nM
Compound 4: only a limit was reported (the forecaster's own chance of this, stated with the estimate: 80%); the middle value sits exactly at the limit.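

Compound 3 and compound 4 each give only a limit of the assay, so the step between them cannot be read. The compounds shown leave open what concentration, if any, would be toxic in this assay: the limit of > 100000 nM in this assay, at which 4 of the 4 values shown sit.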